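Methoxy to Fluoro on the Benzyl Arm, Shorter Linker

This account rests on a few compounds, and the source may have more. Where it says the series, first, only, none or still open, it means among the compounds named here.

Compound 1 `C#CCN(CCCCOc1ccc2ccc(=O)oc2c1)Cc1cccc(OC)c1` and compound 3 `C#CCN(CCCOc1ccc2ccc(=O)oc2c1)Cc1cccc(OC)c1` carry the same propargylamine arm and the same 3-methoxybenzyl group but differ in their cores; the difference between the two cores is not broken down here. In an assay on isolated protein for inhibition of Amine oxidase [flavin-containing] B (Homo sapiens), read by fluorescence and Amplex Red, with stated times of 15 min and 20 min (on this read-out higher numbers stand for weaker inhibition and lower numbers for stronger inhibition), compound 1 gives 2340 nM, and in the same assay compound 3 gives 4590 nM, the highest of the three numbers recorded so far. Compound 2 `C#CCN(CCCCOc1ccc2ccc(=O)oc2c1)Cc1cccc(F)c1` is compound 1 with one change, (fluoro in place of methoxy on an aromatic carbon); in this assay compound 2 gives 1550 nM, which is a 1.5-fold lower number from compound 1 to compound 2 (0.18 log units; within the scatter). Compound 4 `C#CCN(CCCOc1ccc2ccc(=O)oc2c1)Cc1cccc(F)c1` applies the same change to the core of compound 3: fluoro in place of methoxy on an aromatic carbon. The surroundings of the place are described in identical words for both pairs, so this is the same change, seen once before among the compounds in hand. Within the data shown here, the step from compound 3 to compound 4 in this assay is expected to be a 1.5-fold lower number from compound 3 to compound 4 (0.18 log units; within the scatter), resting on the single earlier instance, a 1.5-fold lower number from compound 1 to compound 2 (0.18 log units; within the scatter). Compound 4 is therefore estimated at 3000 nM, with a likely range from 1500 nM to 6000 nM.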

Compound 4, half-maximal inhibitory concentration: 4440 nM
Compound 4: the middle estimate sits 1.5-fold (0.17 log units) below what was measured; the range from low to high includes it.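

On the second core, fluoro in place of methoxy on an aromatic carbon gives, in this assay, a 1.0-fold lower number from compound 3 to compound 4 (0.01 log units; within the scatter). Set beside the earlier step, the change carries across the two cores with no difference that can be read: the same change on two cores in this assay, a 1.5-fold lower number (0.18 log units; within the scatter) from compound 1 to compound 2 and a 1.0-fold lower number (0.01 log units; within the scatter) from compound 3 to compound 4, 1.5-fold (0.16 log units) apart, within the scatter of two such steps. Neither step leaves the scatter, so the two pairs agree only in that 3-fluorobenzyl and 3-methoxybenzyl cannot be told apart on either core; this does not show that the change is without effect in general, and two pairs do not show that it would behave alike on a further core.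

The compounds shown vary the aromatic group only between methoxy and fluoro at this one place, so a chloro or trifluoromethyl group there, or an amine or a carboxylic acid, remains open. Also open, going by these compounds, is whether the same step holds on a core with a longer chain, or with the propargylamine arm replaced by a plain methyl group.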